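Methyl on a ring carbon of compound 1

A few compounds are considered here, and "the series" means these few. Any claim that something is new, unique, unknown or untested is made for them only; others in the source may bear on it.

Compound 1 `C[C@H]1CC(Cl)=C([Si](C)(C)C)[C@@H](C2CCCCC2)O1` is examined in a functional assay on A2780 cells (Homo sapiens) for antiproliferative activity (on this read-out lower numbers stand for stronger inhibition of growth and higher numbers for weaker inhibition of growth), where compound 1 gives 17000 nM. Among the three numbers measured so far this is the second highest. Compound 3 `CC[C@H]1CC(Cl)=C([Si](C)(C)C)[C@@H](C2CCCCC2)O1` gives 16000 nM, the nearest number, and compound 2 `C[C@H]1CC(Cl)=C[C@@H](C2CCCCC2)O1` gives 19000 nM, the furthest; all three sit within the scatter of one another.

Compound 4 `C[C@@H]1O[C@H](C2CCCCC2)C([Si](C)(C)C)=C(Cl)[C@H]1C` is not yet measured. It differs from compound 1 by methyl in place of hydrogen on a saturated ring carbon. Among the compounds with values here, no measured step covers this same change. The closest comparison is a 1.1-fold lower number from compound 1 to compound 3 (0.03 log units; within the scatter), where a methyl also entered in place of hydrogen, though on a saturated chain carbon bound to a saturated ring carbon rather than on the ring itself. The other measured step, a 1.1-fold higher number from compound 1 to compound 2 (0.05 log units; within the scatter), removed the group of 4 heavy atoms from a double-bonded ring carbon and likewise stayed within the scatter. With both known steps flat, the expectation for compound 4 in this assay is no step beyond the scatter, no change at the digits printed from compound 1 to compound 4 (within the scatter). Compound 4 is accordingly estimated at 17000 nM, with a range from 8000 nM to 36000 nM.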

Compound 4, concentration for 50% growth inhibition: 19000 nM
The estimate for compound 4 lay 1.1-fold (0.05 log units) below the measured number; low and high end bracket the measured number.
By their numbers in this assay, from the lowest: compounds 3, 1, 2 and 4 (each within the scatter of the next).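

Methyl in place of hydrogen on a saturated ring carbon, on the ring atom next to the ring atom that bears a chloro group, gives a 1.1-fold higher number from compound 1 to compound 4 (0.05 log units; within the scatter) in this assay, so the flat picture now extends from the earlier chain carbon and double-bonded ring carbon to a saturated carbon of the ring itself. Single changes at these three places on compound 1 all stay within the scatter, and none of the three places stands out from the others on this read-out. Nothing on hand explains why this added methyl leaves the read-out flat.

On these data alone, whether an amine, a carboxylic acid or a longer chain on this saturated ring carbon would produce a step beyond the scatter remains open, as a single methyl says little about larger or different groups at this place. Also open, as far as these compounds go, is what a phenyl ring would do in place of the cyclohexyl group, or a fluoro group in place of the chloro group, both of which stay unchanged across all four compounds.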